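The source may hold more compounds than are shown below. What is called first, only, known or untested is meant among the compounds shown, and "the series" means these compounds.

Values in a functional assay on SK-BR-3 cells (Homo sapiens) for antiproliferative activity (a higher number here means a weaker inhibitor, a lower number a stronger inhibitor), for the three measured compounds:

Compound 1 `CCN(C)CCCOc1ccc2cc(NC(=O)c3ccc(O)c(CC=C(C)C)c3)c(=O)oc2c1C`: 730 nM
Compound 2 `CC(C)=CCc1cc(C(=O)Nc2cc3ccc(OCCCN(C(C)C)C(C)C)c(C)c3oc2=O)ccc1O`: 1600 nM
Compound 3 `CC(C)=CCc1cc(C(=O)Nc2cc3ccc(OCCCNC(C)(C)C)c(C)c3oc2=O)ccc1O`: 660 nM

All three share one core and differ only in the amine that sits at the end of the three-carbon chain hanging from the ring oxygen. Compound 3 has the lowest number of the three, but its gap to compound 1 is small: a 1.1-fold lower number from compound 1 to compound 3 (0.04 log units; within the scatter). Its gap to compound 2 is larger: a 2.4-fold lower number from compound 2 to compound 3 (0.38 log units; beyond the scatter), and likewise a 2.2-fold higher number from compound 1 to compound 2 (0.34 log units; beyond the scatter).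

Compound 4 `CC(C)=CCc1cc(C(=O)Nc2cc3ccc(OCCCNCc4ccccc4)c(C)c3oc2=O)ccc1O` has not yet been measured. It differs from compound 3 in one place: benzyl in place of tert-butyl on an amine nitrogen. The three measured steps all concern the same amine and all stayed modest, so the amine appears to move the numbers only a little, although no benzyl has been seen here. A step of about a 1.2-fold higher number from compound 3 to compound 4 (0.08 log units; within the scatter) is expected, most likely within the scatter or slightly higher. Compound 4 is therefore estimated at 800 nM, with a range from 350 nM to 1900 nM.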

Compound 4, half-maximal inhibitory concentration: 470 nM
For compound 4 the middle estimate is 1.7-fold (0.23 log units) above the measured one; the range from low to high includes it.
By their numbers in this assay, from the lowest: compounds 4, 3 and 1 (each within the scatter of the next); then compound 2.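

In this assay, the amine nitrogen accepts a benzyl group with its six-membered aromatic ring in place of tert-butyl (a 1.4-fold lower number from compound 3 to compound 4 (0.15 log units; within the scatter)), and the comparison with ethyl(methyl)amino reads much the same (a 1.6-fold lower number from compound 1 to compound 4 (0.19 log units; within the scatter)). Diisopropylamino is the amine that stands apart (a 3.4-fold lower number from compound 2 to compound 4 (0.53 log units; beyond the scatter)), yet the number of groups on the nitrogen does not sort these values on its own, since ethyl(methyl)amino also carries two groups and stays within the scatter of benzylamino. No measurement shown here explains these differences.

As far as these compounds go, it remains open whether a ring amine such as piperidine or morpholine, or the plain primary amine, would fit with benzylamino or with diisopropylamino. A fluorine on the benzyl ring or a longer chain to the ring oxygen is equally untested in this set.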